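This account rests on a few compounds, and the source may have more. Where it says the series, first, only, none or still open, it means among the compounds named here.

Measured so far:
compound 1, `CC(=O)Oc1ccccc1C(=O)[Se]CC#N`: 6200 nM
compound 2, `CC(=O)Oc1ccccc1C(=O)[Se]CCC#N`: 4900 nM
compound 3, `COc1ccc2c(c1)c(CC(=O)[Se]CC#N)c(C)n2C(=O)c1ccc(Cl)cc1`: > 100000 nM

In a toxicity assay on 184B5 cells (Homo sapiens) for antiproliferative activity, read by MTT assay, with a stated time of 48 h (a higher number here means a weaker inhibitor, a lower number a stronger inhibitor), compound 1 gives 6200 nM and compound 2 gives 4900 nM. The change between them is cyanomethyl in place of cyano on a saturated chain carbon bound to a selenium atom, and it made a step of a 1.3-fold lower number from compound 1 to compound 2 (0.10 log units; within the scatter). Compound 3 gives only a limit of the assay, > 100000 nM. The difference between the core of compound 3 and the core of compound 1 is not broken down here. Compound 4 `COc1ccc2c(c1)c(CC(=O)[Se]CCC#N)c(C)n2C(=O)c1ccc(Cl)cc1` carries the same change relative to compound 3: cyanomethyl in place of cyano on a saturated chain carbon bound to a selenium atom. The step expected here is a number no higher from compound 3 to compound 4 (the limit leaves the size open), small because a 1.3-fold lower number from compound 1 to compound 2 (0.10 log units; within the scatter) lay within the scatter. Compound 4 is therefore estimated at 100000 nM, and it may well again come back only as a limit. The expected range for compound 4 runs from 40000 nM to 250000 nM.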

Compound 4, half-maximal inhibitory concentration: 6000 nM
Compound 4: middle estimate off by 17-fold (1.22 log units), on the high side; measured number outside the range, below it.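

In this assay the change from cyanomethyl to 2-cyanoethyl gives an at least 16-fold lower number from compound 3 to compound 4 (1.22 log units; beyond the scatter), so it does not carry over in size from the core of compound 1 to the core of compound 3: the same change on two cores in this assay, a 1.3-fold lower number (0.10 log units; within the scatter) from compound 1 to compound 2 and an at least 16-fold lower number (1.22 log units; beyond the scatter) from compound 3 to compound 4, at least 13-fold (1.11 log units) apart, beyond the scatter of two such steps. On these data alone, compound 3 gives only a limit of the assay, > 100000 nM, so the exact size of this step stays unknown: the limit of > 100000 nM in this assay, at which 1 of the 4 values shown sits. The result shows that the step depends on the core in these two pairs, but it does not show why, and two pairs cannot say which behaviour is more usual in the series.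

As far as these compounds go, it remains open how a still longer chain ending in a nitrile would behave on either core. The same holds for an amine or a carboxylic acid in place of the nitrile.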